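N-aryl swap carried onto a second core

This account rests on a few compounds, and the source may have more. Where it says the series, first, only, none or still open, it means among the compounds named here.

Measured in a functional assay on PC-3 cells (Homo sapiens) for cytotoxicity, read by MTT assay, with a stated time of 72 h; on this read-out higher numbers stand for weaker inhibition and lower numbers for stronger inhibition:
compound 1 `Cc1cc(=O)n(-c2cccc(F)c2)nc1C(=O)Nc1ccc(Oc2ncnc3[nH]ccc23)c(F)c1` gives 6680 nM.
compound 2 `Cc1ccc(-n2nc(C(=O)Nc3ccc(Oc4ncnc5[nH]ccc45)c(F)c3)c(C)cc2=O)cc1` gives 20400 nM.
For compound 3 `Cc1cc(=O)n(-c2cccc(F)c2)nc1C(=O)Nc1ccc(Oc2ncnc3c2ccn3C)cc1` only a limit is reported, > 60000 nM.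

Across the first pair the change is 4-methylphenyl in place of 3-fluorophenyl on an aromatic nitrogen, and it produced a 3.1-fold higher number from compound 1 to compound 2 (0.48 log units; beyond the scatter). Compound 4 `Cc1ccc(-n2nc(C(=O)Nc3ccc(Oc4ncnc5c4ccn5C)cc3)c(C)cc2=O)cc1` is the same change made on compound 3, (4-methylphenyl in place of 3-fluorophenyl on an aromatic nitrogen), with the surroundings of the place described in identical words. How the core of compound 3 differs from the core of compound 1 is not broken down here. Compound 3 already sits at the limit of > 60000 nM in this assay, at which 1 of the 3 values shown sits, so no number is available to carry the step from. Carrying the measured step across, the estimated step is a step that the limit leaves unreadable from compound 3 to compound 4, and a further weakening is expected. Compound 4 is estimated at 150000 nM, expected between 60000 nM and 400000 nM, and this assay will most likely again report only a limit.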

Compound 4, half-maximal inhibitory concentration: > 60000 nM
Compound 4: a limit, no number; the forecaster's own chance of this, stated with the estimate: 85%; the middle value is on the limit's open side.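

Within the data shown here, compound 3 and compound 4 each give only a limit in this assay, so no step between them can be read. As far as these compounds go, whether 4-methylphenyl in place of 3-fluorophenyl changes inhibition on the core of compound 3 stays open.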